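Morpholine to Thiomorpholine on a Pyridyl Amidrazone Thiosemicarbazide

This account rests on a few compounds, and the source may have more. Where it says the series, first, only, none or still open, it means among the compounds named here.

Measured compounds:
compound 1 `Cc1cccc(/C(N)=N/NC(=S)N2CCN(c3ccccn3)CC2)n1`, 74.8%
compound 2 `N/C(=N\NC(=S)N1CCOCC1)c1ccccn1`, 15%
compound 3 `Cc1ccnc(/C(N)=N/NC(=S)N2CCOCC2)c1`, 87.4%

In a functional assay on A-375 cells (Homo sapiens) for cytotoxicity, read by MTT assay, with a stated time of 72 h, tested at 30 uM (a higher number here means more inhibition of growth at the concentration tested, a lower number less inhibition of growth), compound 3 gives 87.4%, the highest of the three numbers. The nearest is compound 1 with 74.8%, and the furthest is compound 2 with 15%, both beyond the scatter. Among the measured compounds shown here, the only single-point step among the measured compounds is a number 72.4 percentage points higher from compound 2 to compound 3 (beyond the scatter), a methyl in place of hydrogen on an aromatic carbon.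

Compound 4 `Cc1ccnc(/C(N)=N/NC(=S)N2CCSCC2)c1` differs from compound 3 by thiomorpholin-4-yl in place of morpholin-4-yl on a thiocarbonyl carbon. For the measured compounds named here, no measured step touches this ring; the one step known concerns the methyl, and compound 1 differs from compound 3 in two places at once, so only its value and that of compound 3 can be set side by side. Nothing in the data therefore speaks for a step beyond the scatter in this assay, and the expected change is small, in either direction.

Compound 4 is accordingly expected to reach about 84%, with a range from 62% to 97%, which means an estimated step of a number 3.4 percentage points lower from compound 3 to compound 4 (within the scatter).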

Compound 4, percent growth inhibition at one concentration: 84.9%
Compound 4: the middle estimate sits 0.9 percentage points below what was measured, within the range that was stated.
By their numbers in this assay, from the lowest: compound 2; then compound 1; then compounds 4 and 3 (each within the scatter of the next).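

In this assay the ring on the thiocarbonyl carbon now has a measured step of its own: thiomorpholin-4-yl in place of morpholin-4-yl gives a number 2.5 percentage points lower from compound 3 to compound 4 (within the scatter) and so adds a second kind of single-place change to the one on the aromatic methyl. Sulfur takes the place of oxygen here while the ring size, the heavy-atom count and the counts of donors and acceptors stay as they were, and the read-out stays within the scatter, so for this pair the high growth inhibition does not depend on the ring oxygen. The data at hand offer no measurement that would explain why the two rings read alike.

On these data alone, whether the same exchange would also read alike on the core of compound 2, which lacks the methyl, remains open. Also open, as far as these compounds go, is how this assay would respond to other groups on the thiocarbonyl carbon, such as a piperidine ring, an open-chain dimethylamino group or a morpholine ring carrying a carboxylic acid.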